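The source may report more compounds than this note shows. Statements on the series, on what has been measured and on what is new or still open speak of the compounds shown alone.

Measured compounds and their values:
compound 1, `CCCCCCCCS(=O)(=O)Nc1cc(-c2cccc(Cl)c2)ccc1C(=O)O`, 13800 nM
compound 2, `CCCCCCCCS(=O)(=O)Nc1cc(-c2ccccc2OC)ccc1C(=O)O`, 16100 nM
compound 3, `CCCCCCCCS(=O)(=O)Nc1ccc(-c2cccc(Cl)c2)cc1C(=O)O`, 8900 nM

All three were tested in an assay on mitochondria (strain BALB/c) for inhibition of glycerol-3-phosphate acyltransferase 1, mitochondrial (Mus musculus), read by scintillation counting, with a stated time of 10 min; on this read-out lower numbers stand for stronger inhibition and higher numbers for weaker inhibition. Compound 3 gives the lowest of the three numbers, but its gaps to compound 1 and to compound 2 both fall within the usual scatter, so the three compounds cannot be ranked against one another on these numbers.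

Compound 4, `CCCCCCCCS(=O)(=O)Nc1ccc(-c2ccc(O)cc2)cc1C(=O)O`, has not yet been measured. It differs from compound 3 in one place: 4-hydroxyphenyl in place of 3-chlorophenyl on an aromatic carbon

Among the measured compounds shown here, only one measured step speaks to a change of this kind. Swapping one aryl group for another on the same part of the core, the step of a 1.2-fold higher number from compound 1 to compound 2 (0.07 log units; within the scatter) stayed within the scatter. For the measured compounds named here, that step compared two groups without a hydrogen-bond donor, whereas the 4-hydroxyphenyl group that enters compound 4 carries one, so the comparison is loose, and there is no measured pair that shows what a hydroxy group on this ring does. On this evidence the expected step from compound 3 to compound 4 in this assay is a 1.3-fold higher number from compound 3 to compound 4 (0.13 log units; within the scatter), which means no change beyond the scatter.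

Compound 4 is therefore expected to give about 12000 nM in this assay, with a plausible range from 5000 nM to 30000 nM.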

Compound 4, half-maximal inhibitory concentration: 47300 nM
Compound 4: middle estimate off by 3.9-fold (0.60 log units), on the low side, and the stated range ends below it.
By their numbers in this assay, from the lowest: compounds 3, 1 and 2 (each within the scatter of the next); then compound 4.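

In this assay, among the compounds shown here, the aryl group on this carbon proves able to shift the number, with a 5.3-fold higher number from compound 3 to compound 4 (0.73 log units; beyond the scatter) as the first step here to pass beyond the scatter, while the earlier aryl swap of a 1.2-fold higher number from compound 1 to compound 2 (0.07 log units; within the scatter) stayed within it. That earlier swap exchanged two groups without a hydrogen-bond donor on the other arrangement of the shared core, whereas this change removes the chlorine and brings in a hydroxy group, which carries a hydrogen-bond donor, and the two substituents also stand at different places on the ring. The material shown gives no independent measurement that explains the weaker inhibition of compound 4.

A plain phenyl, a 4-chlorophenyl, a 3-hydroxyphenyl and a 4-methoxyphenyl group on this carbon would help separate the loss of chlorine, the placing of the substituent and the role of the hydroxy hydrogen, none of which this single step can tell apart. From the compounds shown here alone, it also stays open whether a 4-hydroxyphenyl group on the core of compound 1 would give a step of similar size.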